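A few compounds are considered here, and "the series" means these few. Any claim that something is new, unique, unknown or untested is made for them only; others in the source may bear on it.

Measured compounds:
- compound 1 `FC(F)(F)c1ccc(Nc2nc(N3CCC3)nc3sc(Nc4c(Cl)cccc4Cl)nc23)cc1` — 59 nM
- compound 2 `FC(F)(F)c1ccc(Nc2nc(N3CCNCC3)nc3sc(Nc4c(Cl)cccc4Cl)nc23)cc1` — 5000 nM
- compound 3 `CC(C)N1CCN(c2nc(Nc3ccc(C(F)(F)F)cc3)c3nc(Nc4c(Cl)cccc4Cl)sc3n2)CC1` — 184 nM

These three share one core and differ only in the amine on the aromatic carbon of the core. In a functional assay on HEK293 cells for antagonist activity at transient receptor potential cation channel subfamily V member 1 (Homo sapiens), read by calcium flux (a lower number here means a stronger inhibitor, a higher number a weaker inhibitor), compound 3 stands second highest of the three numbers, and its nearest neighbour is compound 1: a 3.1-fold higher number from compound 1 to compound 3 (0.49 log units; beyond the scatter). Its furthest neighbour is compound 2, and the step of a 27-fold lower number from compound 2 to compound 3 (1.43 log units; beyond the scatter) is large. Compound 2 differs from compound 1 by the step of an 85-fold higher number from compound 1 to compound 2 (1.93 log units; beyond the scatter).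

Compound 4 `CCN(CC)c1nc(Nc2ccc(C(F)(F)F)cc2)c2nc(Nc3c(Cl)cccc3Cl)sc2n1` carries the change (diethylamino in place of 4-isopropylpiperazin-1-yl on an aromatic carbon). Among the measured compounds shown here, two measured steps bear on it. The step from compound 2 to compound 3 shows that removing the hydrogen on the ring amine nitrogen lowers the number strongly, and compound 4 has no such hydrogen either. The step from compound 1 to compound 3 shows that going from the small azetidin-1-yl to the larger 4-isopropylpiperazin-1-yl raises the number modestly, and compound 4 returns to a small group with no ring. The expected step from compound 3 to compound 4 in this assay is therefore a modest decrease, a 2.0-fold lower number from compound 3 to compound 4 (0.31 log units; beyond the scatter). Compound 4 is estimated at 90 nM, within a range of 30 nM to 300 nM.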

Compound 4, half-maximal inhibitory concentration: 48 nM
Compound 4: middle estimate off by 1.9-fold (0.27 log units), on the high side; the measured number falls inside the stated range.
By their numbers in this assay, from the lowest: compounds 4 and 1 (each within the scatter of the next); then compound 3; then compound 2.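

In this assay the open-chain diethylamino group and the azetidin-1-yl ring cannot be told apart at this carbon (a 1.2-fold lower number from compound 1 to compound 4 (0.09 log units; within the scatter)), so among the compounds shown a ring on this position is not required to reach the number of compound 1. Taking the 4-isopropylpiperazin-1-yl group away for diethylamino gives a further modest gain (a 3.8-fold lower number from compound 3 to compound 4 (0.58 log units; beyond the scatter)), and set against the unsubstituted piperazin-1-yl group the same change gives the largest step in the set (a 100-fold lower number from compound 2 to compound 4 (2.02 log units; beyond the scatter)), larger than the one isopropyl alone gives (a 27-fold lower number from compound 2 to compound 3 (1.43 log units; beyond the scatter)). Across all four compounds, the two whose amine carries a single nitrogen, compound 1 and compound 4, hold the lowest numbers, and neither piperazine compound goes against this, although the isopropyl group closes much of the gap.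

The compounds shown leave open whether a morpholine ring, a pyrrolidine ring or a longer chain such as dipropylamino would fit the same pattern at this carbon, and whether a single ethyl on the amine would serve as well as two. Nothing available explains why these amines differ as they do.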